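This account rests on a few compounds, and the source may have more. Where it says the series, first, only, none or still open, it means among the compounds named here.

Of the compounds shown here, three have been measured in an assay on Sf9 cells for inhibition of protein deacetylase HDAC6 (Homo sapiens), read by fluorescence, with a stated time of 40 min, tested at 100 nM (on this read-out lower numbers stand for less inhibition and higher numbers for more inhibition at the one concentration tested (going by the name of the read-out)), and all three share the same core, differing only in the two aromatic groups attached to it. Compound 1 `COc1ccc(-c2nc(CNc3ccc(C(=O)NO)cc3)n(-c3ccccc3)n2)cc1` gives 77.6%, compound 2 `O=C(NO)c1ccc(NCc2nc(-c3ccccc3)nn2-c2ccccc2Cl)cc1` gives 64.6%, and compound 3 `O=C(NO)c1ccc(NCc2nc(-c3ccco3)nn2-c2ccccc2)cc1` gives 59.9%. Compound 2 thus stands second highest of the three numbers; its nearest neighbour is compound 3, which lies within the scatter of it, while compound 1 lies beyond the scatter above it.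

Within the data shown here, the only step between two compounds that differ in a single place is a number 17.7 percentage points lower from compound 1 to compound 3 (beyond the scatter), a modest fall that concerns the group on an aromatic carbon of the core.

The unmeasured compound 4 `O=C(NO)c1ccc(NCc2nc(-c3ccccc3)nn2-c2ccc(Cl)cc2)cc1` differs from compound 2 in another way: 4-chlorophenyl in place of 2-chlorophenyl on an aromatic nitrogen. Among the measured compounds shown here, the two compounds contain the same atoms, joined differently, and the change sits on an aromatic nitrogen rather than on the aromatic carbon that the one measured step concerns. For the measured compounds named here, no measured pair shows what moving the chlorine around this ring does, so the single measured step does not bear on it. With nothing pointing either way, the expectation for this assay is a step within the scatter, expected as a number 0.6 percentage points lower from compound 2 to compound 4 (within the scatter), so that compound 4 is estimated at 64%, with a range from 48% to 80%.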

Compound 4, a percentage reported as inhibition, at one concentration (the size of the read-out at that concentration, not a potency): 55.4%
For compound 4 the middle estimate is 8.6 percentage points above the measured one, and the stated range covers the measured number.
By their numbers in this assay, from the lowest: compounds 4, 3 and 2 (each within the scatter of the next); then compound 1.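

In this assay, moving the chlorine around the ring on the aromatic nitrogen of the core gives a number 9.2 percentage points lower from compound 2 to compound 4 (within the scatter). Among these compounds, this is the first measured pair that changes only this position, as the earlier step concerned the group on an aromatic carbon of the core. Since 2-chlorophenyl and 4-chlorophenyl hold the same atoms, joined differently, this pair shows that the swap leaves the two compounds indistinguishable in this read-out, at the one concentration tested; nothing measured here speaks to what lies behind that reading.

The compounds shown leave open what other groups would do on this ring, for example an amine or a carboxylic acid in the place of the chlorine, and whether the outcome of moving the chlorine holds when the aromatic carbon of the core carries something other than phenyl, such as furan-2-yl or 4-methoxyphenyl. They also leave open how either chlorinated ring compares with a plain phenyl ring on the aromatic nitrogen while that carbon bears phenyl.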